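Methyl on the aminomethyl carbon: compound 2 to compound 3

A few compounds are considered here, and "the series" means these few. Any claim that something is new, unique, unknown or untested is made for them only; others in the source may bear on it.

Of the compounds shown here, two carry numbers so far. Compound 1 `CCC(=O)N1C[C@@H](C(=O)N2CCN(c3ccc(C)cc3[C@@H](NC(=O)CCN(C)C)C(C)C)CC2)[C@H](c2ccc(Cl)cc2)C1` gives 129% in a functional assay on CHO cells with Melanocortin receptor 4 (Homo sapiens) as the target, read by cAMP accumulation; on this read-out lower numbers stand for smaller maximal responses and higher numbers for larger maximal responses. Compound 2 `Cc1ccc(N2CCN(C(=O)[C@@H]3CN(C4CCOCC4)C[C@H]3c3ccc(Cl)cc3)CC2)c([C@@H](NC(=O)CN)C(C)C)c1` gives 114% in this assay, the lowest of the two numbers; the nearest, compound 1, stands higher by a difference beyond the usual scatter. Among the compounds with values here, no two measured compounds differ in one place only, so no single-change step is available as a guide.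

Compound 3 `Cc1ccc(N2CCN(C(=O)[C@@H]3CN(C4CCOCC4)C[C@H]3c3ccc(Cl)cc3)CC2)c([C@@H](NC(=O)[C@@H](C)N)C(C)C)c1` is not yet measured. It differs from compound 2 by methyl in place of hydrogen on a saturated chain carbon bound to an amine nitrogen and a carbonyl carbon, aminomethyl becoming 1-aminoethyl. Nothing in the measured pair bears on this change. The expectation is a step of no size beyond the scatter, in neither direction. Compound 3 is expected to give 114% in this assay, within 96% to 132%, which amounts to an expected step of no change at the digits printed from compound 2 to compound 3 (within the scatter) lying inside the scatter.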

Compound 3, intrinsic activity: the largest response reached, in percent of the reference agonist's: 56%
The estimate for compound 3 lay 58 percentage points above the measured number; measured number outside the range, below it.
By their numbers in this assay, from the lowest: compound 3; then compound 2; then compound 1.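

In this assay, within the data shown here, the change of aminomethyl to 1-aminoethyl gives a number 58 percentage points lower from compound 2 to compound 3 (beyond the scatter), the only single-change step so far. It shows that the maximal response is sensitive at this position: one methyl, with no ring and no hydrogen-bond donors or acceptors, is enough to bring compound 3 to 56% in this read-out. No measured evidence bears on the reason for this drop.

From the compounds shown here alone, it remains open whether the response falls further with a longer chain on the same carbon, as in 1-aminopropyl, or with a second methyl, as in 1-amino-1-methylethyl. Going by these compounds, it is also open whether the opposite configuration at this carbon gives a step of similar size.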